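Dimethylphenyl for Dichlorophenyl on a Longer Linker

A few compounds are considered here, and "the series" means these few. Any claim that something is new, unique, unknown or untested is made for them only; others in the source may bear on it.

Compound 1 `Cc1cccc(N2CCN(CCCNc3nc(NCc4ccco4)c4ccccc4n3)CC2)c1C` in a functional assay on HCT-116 cells (Homo sapiens) for cytotoxicity, read by MTT assay, with a stated time of 2 days (a higher number here means a weaker inhibitor, a lower number a stronger inhibitor), gives 770 nM.
Compound 2 `Clc1cccc(N2CCN(CCCNc3nc(NCc4ccco4)c4ccccc4n3)CC2)c1Cl` in this assay gives 3360 nM.
Compound 3 `Clc1cccc(N2CCN(CCCCNc3nc(NCc4ccco4)c4ccccc4n3)CC2)c1Cl` in this assay gives 3200 nM.

The change 2,3-dimethylphenyl in place of 2,3-dichlorophenyl on an amine nitrogen in a ring has been measured once, and it gave a 4.4-fold lower number from compound 2 to compound 1 (0.64 log units; beyond the scatter). The same change, (2,3-dimethylphenyl in place of 2,3-dichlorophenyl on an amine nitrogen in a ring), turns compound 3 into compound 4 `Cc1cccc(N2CCN(CCCCNc3nc(NCc4ccco4)c4ccccc4n3)CC2)c1C`, and the two places are described word for word alike. How the core of compound 3 differs from that of compound 2 is not broken down here; their values in this assay lie within the scatter of each other.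

For compound 4, the expected step is a 4.0-fold lower number from compound 3 to compound 4 (0.60 log units; beyond the scatter), set beside the measured 4.4-fold lower number from compound 2 to compound 1 (0.64 log units; beyond the scatter). Among the compounds with values here, the expectation rests on compound 3 at 3200 nM and on the step of a 4.4-fold lower number from compound 2 to compound 1 (0.64 log units; beyond the scatter), with only one instance of the change to lean on. Compound 4 is thus expected to give about 800 nM, estimated between 350 nM and 1800 nM.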

Compound 4, half-maximal inhibitory concentration: 840 nM
Compound 4: the middle estimate sits 1.1-fold (0.02 log units) below what was measured; the measured number falls inside the stated range.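

In this assay, 2,3-dimethylphenyl in place of 2,3-dichlorophenyl gave a 3.8-fold lower number from compound 3 to compound 4 (0.58 log units; beyond the scatter). The change therefore carried over to the second core with much the same size as on the first: the same change on two cores in this assay, a 4.4-fold lower number (0.64 log units; beyond the scatter) from compound 2 to compound 1 and a 3.8-fold lower number (0.58 log units; beyond the scatter) from compound 3 to compound 4, 1.1-fold (0.06 log units) apart, within the scatter of two such steps. Within the data shown here, this agreement rests on only two cores and one assay, so it does not show that the step would hold across the wider series, nor does it explain why the number falls.

The compounds shown leave open how the step would behave on a core with a longer chain. They also leave open whether a phenyl ring bearing methoxy or fluorine on the same ring nitrogen would give a similar result.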